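Coumarin-bearing sidnone analogues: a cytotoxicity series with one open gap

This account rests on a few compounds, and the source may have more. Where it says the series, first, only, none or still open, it means among the compounds named here.

Three compounds share a core that carries a coumarin on one side and a charge-separated five-membered ring on the other. Compound 1 `O=c1oc2ccccc2cc1-c1cn2nc(-c3c([O-])[o+]nn3-c3ccc(Cl)cc3)sc2n1` was tested in a functional assay on HT-29 cells (Homo sapiens) for cytotoxicity, read by sulforhodamine B assay; on this read-out lower numbers stand for higher toxicity in this test and higher numbers for lower toxicity in this test. In this assay compound 1 reaches only the limit of > 80 ug/mL, not a number. Compound 2 `COc1ccc(-n2n[o+]c([O-])c2-c2nn3cc(-c4cc5ccccc5oc4=O)nc3s2)cc1` gives in this assay only the limit > 70 ug/mL. Compound 3 `COc1ccc(-n2n[o+]c([O-])c2-c2nn3cc(-c4cc5cc(Br)ccc5oc4=O)nc3s2)cc1` likewise gives in this assay only the limit > 80 ug/mL. The change from compound 2 to compound 1 is chloro in place of methoxy on an aromatic carbon, and its step that the two limits leave unreadable from compound 2 to compound 1 because of the limit of > 70 ug/mL in this assay, at which 1 of the 3 values shown sits, and (the limit of > 80 ug/mL in this assay, at which 2 of the 3 values shown sit). The cores of compound 2 and compound 3 differ by bromo in place of hydrogen on an aromatic carbon, with the step that the two limits leave unreadable from compound 2 to compound 3.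

Compound 4 `O=c1oc2ccc(Br)cc2cc1-c1cn2nc(-c3c([O-])[o+]nn3-c3ccc(Cl)cc3)sc2n1` is not yet measured. It differs from compound 3 by chloro in place of methoxy on an aromatic carbon, the same change already seen from compound 2 to compound 1. The step from compound 3 to compound 4 in this assay is expected to be a step that the limit leaves unreadable from compound 3 to compound 4, an expectation resting on compound 1 with > 80 ug/mL. Compound 4 is estimated at 90 ug/mL, likely again a limit.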

Compound 4, concentration lethal to 50% of the cells: > 70 ug/mL
Compound 4: only a limit was reported; the forecaster's own chance of this, stated with the estimate: 80%; the middle value lies beyond the limit too.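

Going by these compounds alone, compound 4 gives only a limit in this assay, as do compound 1 and compound 3, so no step from compound 3 or compound 1 to compound 4 can be read. The compounds shown leave open whether chloro in place of methoxy, or bromo in place of hydrogen, changes cytotoxicity at all.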